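Reversing a methoxy-to-amino-acid swap on a quinone core

A few compounds are considered here, and "the series" means these few. Any claim that something is new, unique, unknown or untested is made for them only; others in the source may bear on it.

Compound 1 `CC1=CCC[C@](C)(CC/C(C)=C/CC2=C(O)C(=O)C=C(N[C@@H](C(=O)O)[C@@H](C)O)C2=O)[C@@H]1C`: > 10 ug/mL
Compound 2 `CC1=CCC[C@](C)(CC/C(C)=C/CC2=C(O)C(=O)C=C(N[C@@H](C(=O)O)C(C)C)C2=O)[C@@H]1C`: 3 ug/mL
Compound 3 `COC1=CC(=O)C(O)=C(C/C=C(\C)CC[C@@]2(C)CCC=C(C)[C@H]2C)C1=O`: 2 ug/mL

In an ADME assay on L1210 cells (Mus musculus) for cytotoxicity, with a stated time of 48 h (on this read-out lower numbers stand for stronger inhibition and higher numbers for weaker inhibition), compound 1 gives only a limit, > 10 ug/mL. Compound 3 has the lowest number of the two finished values, though compound 2 sits within the scatter of it. Compound 4 `CC1=CCC[C@](C)(CC/C(C)=C/CC2=C(O)C(=O)C=C(N[C@@H](C(=O)O)[C@H](C)O)C2=O)[C@@H]1C` carries the change ((1-carboxy-2-hydroxypropyl)amino in place of methoxy on a double-bonded ring carbon), with 2 defined stereocentres in the entering group. The same group was exchanged the other way in an at least 5.0-fold lower number from compound 1 to compound 3 (0.69 log units; beyond the scatter), so the reverse step should move the number up; a 1.5-fold lower number from compound 2 to compound 3 (0.18 log units; within the scatter) shows a related amino group costing little. Compound 4 is therefore expected to show a 4.0-fold higher number from compound 3 to compound 4 (0.60 log units; beyond the scatter), a weaker result, and its estimated value is 8 ug/mL with a range from 3 ug/mL to 20 ug/mL.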

Compound 4, half-maximal inhibitory concentration: > 10 ug/mL
Compound 4: only a limit was reported; the forecaster's own chance of this, stated with the estimate: 45%; middle value at least 1.2-fold (0.09 log units) away from the limit.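

In this assay compound 4 gives > 10 ug/mL, which is a limit of the assay. Placing the (1-carboxy-2-hydroxypropyl)amino group on this double-bonded ring carbon gives an at least 5.0-fold higher number from compound 3 to compound 4 (0.69 log units; beyond the scatter), while 1-hydroxyethyl in place of isopropyl gives an at least 3.3-fold higher number from compound 2 to compound 4 (0.52 log units; beyond the scatter), so the weak result seen with compound 1 also holds for the other drawn configuration. Any effect of that configuration cannot be read because both compounds stop at the same limit: the limit of > 10 ug/mL in this assay, at which 2 of the 4 values shown sit.

The compounds shown leave open how a plain amine would read at this ring carbon. They also leave open whether an amide in place of the carboxylic acid would change the result.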